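The source may report more compounds than this note shows. Statements on the series, on what has been measured and on what is new or still open speak of the compounds shown alone.

Measured in a functional assay on DU-145 cells (Homo sapiens) for inhibition, read by trypan blue exclusion, with a stated time of 96 h; a higher number here means a weaker inhibitor of growth, a lower number a stronger inhibitor of growth:
- compound 1 `Cc1ccc(S(=O)(=O)/C(=C/c2sccc2C)C(=O)c2ccc(Cl)cc2)cc1`: 10000 nM
- compound 2 `CCOc1ccc(/C=C(\C(=O)c2ccc(Cl)cc2)S(=O)(=O)Cc2ccc(C)cc2)cc1OC`: 10000 nM

Level with compound 1, compound 2 stands at 10000 nM. Compound 3 `Cc1ccc(CS(=O)(=O)/C(=C/c2sccc2C)C(=O)c2ccc(Cl)cc2)cc1` carries 3-methylthiophen-2-yl in place of 4-ethoxy-3-methoxyphenyl on a double-bonded chain carbon bound to a double-bonded chain carbon. Among the measured compounds shown here, no measured pair isolates this change, so the expectation has little to rest on. The expected step in this assay is a 1.4-fold lower number from compound 2 to compound 3 (0.15 log units; within the scatter), leaning toward a lower number but not beyond the scatter. Compound 3 is estimated at 7000 nM, with an expected range of 1500 nM to 15000 nM.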

Compound 3, concentration for 50% growth inhibition: 25000 nM
Compound 3: the middle estimate sits 3.6-fold (0.55 log units) below what was measured, and the stated range ends below it.
By their numbers in this assay, from the lowest: compounds 1 and 2 (each within the scatter of the next); then compound 3.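

In this assay the change to 3-methylthiophen-2-yl on a double-bonded chain carbon bound to a double-bonded chain carbon gives a 2.5-fold higher number from compound 2 to compound 3 (0.40 log units; beyond the scatter) with 4-methylbenzyl held on the sulfonyl sulfur, so this position responds to the group it carries. With 3-methylthiophen-2-yl held fixed, 4-methylbenzyl in place of 4-methylphenyl on a sulfonyl sulfur gives a 2.5-fold higher number from compound 1 to compound 3 (0.40 log units; beyond the scatter) and shows that the sulfonyl substituent also changes the read-out. No available evidence bears on the reason for either step.

On these data alone, whether either step holds with the other group changed remains open. So does how an amine or a longer chain on the sulfonyl sulfur would read.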